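Swapping the Sulfonamide Tail of a Dioxygenase Inhibitor

The compounds below may be only part of what the source reports. "The series", "measured", "known", "first", "only" and "open" are said of these compounds alone.

Of the compounds shown here, two built on a shared core have so far been tested in an assay on isolated protein for inhibition of Indoleamine 2,3-dioxygenase 1 (Homo sapiens), read by fluorescence, with a stated time of 60 min; a higher number here means a weaker inhibitor, a lower number a stronger inhibitor. Compound 1, `NS(=O)(=O)NNc1nonc1/C(=N/O)Nc1ccc(F)c(Br)c1`, gives 218 nM. Compound 2, `O=S(=O)(CCNc1nonc1/C(=N/O)Nc1ccc(F)c(Br)c1)NCC1CC1`, gives 312 nM. Compound 2 holds the higher of the two numbers, yet its gap to compound 1 lies within the scatter of repeated measurements, so the two values cannot be told apart, and neither compound can be called the stronger inhibitor.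

Compound 3, `CN(C)S(=O)(=O)CCCNc1nonc1/C(=N/O)Nc1ccc(F)c(Br)c1`, has not yet been measured. It differs from compound 2 in one place: (dimethylsulfamoyl)methyl in place of (cyclopropylmethyl)sulfamoyl on a saturated chain carbon, two bonds along the chain from a nitrogen on an aromatic ring. The hydrogen-bond donor of the tail is lost, the acceptor count is kept, and the sulfur-bearing group moves one bond further along the chain.

For the measured compounds named here, no step between measured compounds is available, so there is no precedent for how large such a change might read. The expected step of a 1.1-fold higher number from compound 2 to compound 3 (0.05 log units; within the scatter) is small, with no direction beyond the scatter. Compound 3 is therefore estimated at 350 nM, with a range from 150 nM to 800 nM.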

Compound 3, half-maximal inhibitory concentration: 97 nM
Estimate against measurement, compound 3: 3.6-fold (0.56 log units) above; the measured number lies below the stated range.
By their numbers in this assay, from the lowest: compound 3; then compounds 1 and 2 (each within the scatter of the next).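

In this assay, the tail proves able to move the number: a 3.2-fold lower number from compound 2 to compound 3 (0.51 log units; beyond the scatter) comes with (dimethylsulfamoyl)methyl in place of (cyclopropylmethyl)sulfamoyl on a saturated chain carbon, two bonds along the chain from a nitrogen on an aromatic ring. That single change removes the hydrogen-bond donor and the three-membered ring of the group that leaves, while the hydrogen-bond acceptor count stays the same. The other comparison points the same way, with a 2.2-fold lower number from compound 1 to compound 3 (0.35 log units; beyond the scatter) for 3-(dimethylsulfamoyl)propyl in place of sulfamoylamino on a nitrogen on an aromatic ring, so a tail now stands apart beyond the scatter, which the earlier pair did not show. Nothing measured here gives a reason for either step.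

The step from (cyclopropylmethyl)sulfamoyl to (dimethylsulfamoyl)methyl changes the donor, the ring and the place of the sulfur-bearing group all at once, and the compounds shown do not separate these three. As far as these compounds go, how an amine or a carboxylic acid in place of the dimethylsulfamoyl group would read also remains open, as does the effect of a longer chain.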